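Benzyl to Isobutyl Ether: Expected Effect on Growth Inhibition

The source may hold more compounds than are shown below. What is called first, only, known or untested is meant among the compounds shown, and "the series" means these compounds.

Compound 1 `O=C(/C=C/c1ccc(O)cc1)c1c(O)cccc1OCc1ccccc1`: > 30000 nM
Compound 2 `CC(C)(C)CCOc1cccc(O)c1C(=O)/C=C/c1ccc(C(=O)O)cc1`: 11200 nM

In a functional assay on MDA-MB-231 cells (Homo sapiens) for antiproliferative activity, read by sulforhodamine B assay (a higher number here means a weaker inhibitor of growth, a lower number a stronger inhibitor of growth), compound 1 gives only a limit, > 30000 nM, so its true potency is not known beyond that bound. Compound 2 stands at 11200 nM in this assay, a measured number rather than a limit; because of the limit of > 30000 nM in this assay, at which 1 of the 2 values shown sits, compound 1 cannot be placed relative to compound 2 with any confidence. Within the data shown here, no step between these two measured compounds can be read, since they differ in more than one place.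

Compound 3 `CC(C)COc1cccc(O)c1C(=O)/C=C/c1ccc(O)cc1` has not been measured. It differs from compound 1 by isopropyl in place of phenyl on a saturated chain carbon bound to an oxygen on an aromatic ring. Among the measured compounds shown here, with no measured step of this kind to lean on, the change from compound 1 to compound 3 is expected to be small, no larger than the usual scatter, and compound 1 is the only anchor for it. Compound 3 is expected at 25000 nM, within 6000 nM to 80000 nM, which is the expected step of an at least 1.2-fold lower number from compound 1 to compound 3 (0.07 log units; that floor lies within the scatter).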

Compound 3, concentration for 50% growth inhibition: 3520 nM
Beside the measured number, compound 3's estimate is 7.1-fold (0.85 log units) above it; the measured number lies below the stated range.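

In this assay, the place on a saturated chain carbon bound to an oxygen on an aromatic ring now has its first readable step: isopropyl in place of phenyl gives an at least 8.5-fold lower number from compound 1 to compound 3 (0.93 log units; beyond the scatter). The phenyl ring at this place is therefore not needed for growth inhibition on the shared core, and the smaller isobutoxy chain does better than benzyloxy. The true size of the step stays unknown, and only its floor can be read, because compound 1 stands at a limit and not at a number: the limit of > 30000 nM in this assay, at which 1 of the 3 values shown sits.

The compounds shown leave open whether the gain belongs to isobutyl itself or would carry over to other groups at this place, such as a straight butyl chain or a chain ending in an amine. They also leave open why the change acts as it does.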